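A few compounds are considered here, and "the series" means these few. Any claim that something is new, unique, unknown or untested is made for them only; others in the source may bear on it.

Working notes on the series. In a functional assay on LOX IMVI cells (Homo sapiens) for inhibition, read by sulforhodamine B assay, with a stated time of 48 h (on this read-out higher numbers stand for lower toxicity in this test and lower numbers for higher toxicity in this test), compound 1 `COc1cc(C)cc(-c2nn(CC#N)cc2-c2ccc(-c3cccc(C(C)=O)c3)nc2)c1` reaches only a limit of the assay, > 100000 nM. Compound 2 `Cc1cc(O)cc(-c2nn(CC#N)cc2-c2ccnc(-c3ccc(Oc4ccccc4)cc3)c2)c1` gives 6130 nM in this assay. Within what has been measured, compound 2 holds the only number shown; the other entry is a limit, as the limit of > 100000 nM in this assay, at which 1 of the 2 values shown sits, records, so no step between measured compounds is available and no direction of change for this assay has been established.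

Compound 3 `Cc1cc(O)cc(-c2nn(CC#N)cc2-c2ccnc(-c3ccc(N(C)C)cc3)c2)c1` is yet to be measured. It differs from compound 2 by dimethylamino in place of phenoxy on an aromatic carbon. For the measured compounds named here, with no measured step to lean on, the size of the step from compound 2 to compound 3 in this assay is uncertain; an outcome not far beyond the usual scatter, in either direction, is the working assumption, with a slight lean toward a higher concentration. The step from compound 2 to compound 3 is expected to be a 1.5-fold higher number from compound 2 to compound 3 (0.17 log units; within the scatter). For compound 3 the estimate in this assay is 9000 nM, with a range from 2000 nM to 40000 nM.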

Compound 3, concentration lethal to 50% of the cells: 47700 nM
The estimate for compound 3 lay 5.3-fold (0.72 log units) below the measured number, outside the stated range (above it).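

For the compounds shown here, this is the first step that can be read: at the aromatic carbon para to a large group, dimethylamino in place of phenoxy gives a 7.8-fold higher number from compound 2 to compound 3 (0.89 log units; beyond the scatter) in this assay, so the number on this read-out depends on the group held at this position. The change removes a six-membered aromatic ring of carbon only and goes from 7 heavy atoms to 3, with the counts of hydrogen-bond donors and acceptors unchanged, so on this single pair lower toxicity in this test goes with the smaller group without a ring. Nothing measured here gives a reason for the step, and the loss of the ring, the loss of size and the exchange of oxygen for nitrogen remain unseparated.

A methoxy group, a benzyloxy group or a morpholine ring on the same carbon would begin to separate those three changes. Differing from the others in more than one place, compound 1 stands only as a limit of the assay, > 100000 nM, and adds no step.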